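The source may hold more compounds than are shown below. What is called first, only, known or untested is meant among the compounds shown, and "the series" means these compounds.

In an assay on Sf9 cells for inhibition of Hormone-sensitive lipase (Homo sapiens), read by spectrophotometry, with a stated time of 5 min, tested at 1 uM (on this read-out lower numbers stand for less inhibition and higher numbers for more inhibition at the one concentration tested (going by the name of the read-out)), compound 1 `CC1(C)OB(c2ccccc2OCc2ccc(Oc3ccc(C(F)(F)F)cn3)cc2)OC1(C)C` gives 81%, the higher of the two numbers obtained so far; compound 2 `CC1(C)OB(c2cccc(OCc3ccc(Oc4ccc(C(F)(F)F)cn4)cc3)c2)OC1(C)C` gives 59% in this assay, a gap that lies beyond the usual scatter. Compound 3 `O=C(c1ccccc1OCc1ccc(Oc2ccc(C(F)(F)F)cn2)cc1)C(F)(F)F` has not yet been tested in this assay. Compared with compound 1 it carries a group of 6 heavy atoms (2 carbon, 1 oxygen, 3 fluorine; no ring) in place of a group of 9 heavy atoms (6 carbon, 1 boron, 2 oxygen; one five-membered non-aromatic ring with 3 hetero atoms), on an aromatic carbon. Among the measured compounds shown here, no measured pair covers an exchange of this kind, and the expectation rests on the extent of the change alone: a moderate decrease is expected, a number 13 percentage points lower from compound 1 to compound 3 (beyond the scatter). Compound 3 is accordingly estimated to give 68% in this assay, within a range from 40% to 92%.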

Compound 3, a percentage reported as inhibition, at one concentration (the size of the read-out at that concentration, not a potency): 1%
The estimate for compound 3 lay 67 percentage points above the measured number, outside the stated range (below it).
By their numbers in this assay, from the lowest: compound 3; then compound 2; then compound 1.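

With (trifluoromethyl)carbonyl in place of the boron-bearing five-membered ring, on this aromatic carbon ortho to a large group, this assay shows a number 80 percentage points lower from compound 1 to compound 3 (beyond the scatter). The part shared by compound 1 and compound 3 is therefore not enough on its own to give inhibition at the tested concentration, and the outcome depends strongly on the group at this position. Nothing measured here accounts for the size of this step. The compounds shown leave open how a free boronic acid, a carboxylic acid or a nitrile at this position would read. They also cannot separate the contribution of the boron atom from that of its ring.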